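The compounds below may be only part of what the source reports. "The series", "measured", "known", "first", "only" and "open" are said of these compounds alone.

Three compounds set the scene. Compound 1 `O=C(NCc1ccco1)c1ccccc1OCc1ccccc1` gives 49000 nM in an assay on lysate for inhibition of phosphatidylcholine:ceramide cholinephosphotransferase 2 (Homo sapiens), read by HPLC, with stated times of 30 min and 2 h; a higher number here means a weaker inhibitor, a lower number a stronger inhibitor. Within the data shown here, compound 2 `O=C(Nc1ccccn1)c1ccccc1OCc1ccccc1` gives 11700 nM in this assay, and the single measured step, a 4.2-fold lower number from compound 1 to compound 2 (0.62 log units; beyond the scatter), changes the amide nitrogen's substituent. Compound 3 `Cc1ccccc1COc1ccccc1C(=O)Nc1cccnc1` gives 1500 nM, the lowest of the three numbers; it sits beyond the scatter from both compound 2 and compound 1, though compound 3 differs from compound 2 in more than one place, so those two values can only be compared, not read as a single step.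

Compound 4 `Cc1ccc(Cl)cc1COc1ccccc1C(=O)Nc1cccnc1` is the next candidate. The change from compound 3 is chloro in place of hydrogen on an aromatic carbon. Among the measured compounds shown here, no measured step touches the benzyl ether side of the core; the one known step, a 4.2-fold lower number from compound 1 to compound 2 (0.62 log units; beyond the scatter), concerns the amide side and so offers no direct guide. A small substituent added on an aromatic carbon is therefore expected to move this assay modestly at most, and compound 4 is estimated at 800 nM, between 250 nM and 2500 nM. The expected step is a 1.9-fold lower number from compound 3 to compound 4 (0.27 log units; within the scatter), a slight gain that may not clear the scatter.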

Compound 4, half-maximal inhibitory concentration: 1100 nM
Estimate against measurement, compound 4: 1.4-fold (0.14 log units) below; measured number inside the range.
By their numbers in this assay, from the lowest: compounds 4 and 3 (each within the scatter of the next); then compound 2; then compound 1.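

Chloro in place of hydrogen on this aromatic carbon, para to the methyl group, gives a 1.4-fold lower number from compound 3 to compound 4 (0.13 log units; within the scatter) in this assay. Among these compounds, this is the first measured step on the benzyl ether side of the shared core, where the earlier compounds offered only a step on the amide side. It shows that going from 2-methylphenyl to 5-chloro-2-methylphenyl is tolerated here, with a chlorine atom added and no separable change in the read-out, and no measurement given here explains this result. On these data alone, whether a larger or differently built group at this carbon, such as a methoxy group, an amine or a carboxylic acid, would also leave the number within the scatter remains open. Also open, as far as these compounds go, is how much of the gap between compound 2 and compound 3 belongs to the methyl group and how much to the amide side.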